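Swapping a cyanophenyl for a methylsulfonyl pyridinyl ether

A few compounds are considered here, and "the series" means these few. Any claim that something is new, unique, unknown or untested is made for them only; others in the source may bear on it.

Measured so far:
Compound 1 `CC(C)(C)OC(=O)N1CCC(O[C@H]2CC[C@H](Oc3ccc(S(C)(=O)=O)cc3)CC2)CC1` gives 120% in a functional assay on isolated protein for agonist activity at Glucose-dependent insulinotropic receptor (Rattus norvegicus), read by HTRF and cAMP accumulation; a lower number here means a smaller maximal response, a higher number a larger maximal response.
Compound 2 `CC(C)(C)OC(=O)N1CCC(O[C@H]2CC[C@H](Oc3ccc(S(C)(=O)=O)cc3F)CC2)CC1` gives 119% in this assay.
Compound 3 `CC(C)(C)OC(=O)N1CCC(O[C@H]2CC[C@H](Oc3ccc(C#N)cc3)CC2)CC1` gives 106% in this assay.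

Compound 3 stands lowest of the three in this assay; its nearest neighbour is compound 2 and the furthest is compound 1, both beyond the scatter. Compound 4 `CC(C)(C)OC(=O)N1CCC(O[C@H]2CC[C@H](Oc3ccc(S(C)(=O)=O)cn3)CC2)CC1` has not yet been measured. It differs from compound 3 in one place: 5-(methylsulfonyl)pyridin-2-yl in place of 4-cyanophenyl on an oxygen on a saturated carbon.

For the measured compounds named here, one measured step bears directly on this change. The step of a number 14 percentage points lower from compound 1 to compound 3 (beyond the scatter) shows that exchanging the methylsulfonyl for a cyano group lowered the maximal response modestly, so putting the methylsulfonyl group back is expected to recover roughly that amount. The step of a number 1 percentage points lower from compound 1 to compound 2 (within the scatter) shows that a small change on the aromatic ring left the response within the scatter. Going by the values given here, no measured pair tells what the ring with one hetero atom does, so that part stays uncertain. Compound 4 is therefore expected to reach about 117%, between 100% and 134%, a step of a number 11 percentage points higher from compound 3 to compound 4 (beyond the scatter) upward.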

Compound 4, largest response reached (Emax), in percent of the reference or control that the assay uses: 108%
Estimate against measurement, compound 4: 9 percentage points above; the measured number falls inside the stated range.
By their numbers in this assay, from the lowest: compounds 3 and 4 (each within the scatter of the next); then compounds 2 and 1 (each within the scatter of the next).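

Exchanging 4-cyanophenyl for 5-(methylsulfonyl)pyridin-2-yl gives a number 2 percentage points higher from compound 3 to compound 4 (within the scatter) in this assay and so does not restore the response seen with the methylsulfonyl group on a ring of carbon only. Changing only the ring while keeping the methylsulfonyl group gives a number 12 percentage points lower from compound 1 to compound 4 (beyond the scatter) and shows that, in these compounds, the response at this position depends on the aromatic ring as well as on the group it carries. Nothing available explains this difference between the two rings.

Going by these compounds, it remains open whether a nitrile on the ring with one hetero atom would behave like the methylsulfonyl group there. The effect of an amine or a carboxylic acid at that same place on the ring is also unknown.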